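Adding a methyl to a low-clearance compound

The compounds below may be only part of what the source reports. "The series", "measured", "known", "first", "only" and "open" are said of these compounds alone.

Measured so far in an ADME assay on the whole organism (Rattus norvegicus, strain Sprague-Dawley) for pharmacokinetics, using cassette dosing, at a dose of 0.5 mg/kg by the intravenous route; on this read-out lower numbers stand for slow clearance and higher numbers for fast clearance:
- compound 1 `COc1ccc(N2CCN(C(=O)C(=O)Nc3ccc4[nH]c(=O)oc4c3)CC2)cc1` gives "not determined" (no result reported)
- compound 2 `O=C(Nc1ccc2[nH]c(=O)oc2c1)C(=O)N1CCN(c2ccc(F)c(F)c2)CC1` gives 4 mL/min/kg
- compound 3 `O=C(Nc1ccc2[nH]c(=O)oc2c1)C(=O)N1CCN(c2ccc(C(F)(F)F)c(F)c2)CC1` gives 5.6 mL/min/kg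

Compound 2 and compound 3 lie within the scatter of each other, and compound 1 has no number to compare. Compound 4 `C[C@@H]1CN(c2ccc(F)c(F)c2)CCN1C(=O)C(=O)Nc1ccc2[nH]c(=O)oc2c1` differs from compound 2 by methyl in place of hydrogen on a saturated ring carbon. Within the data shown here, only one measured step exists, a 1.4-fold higher number from compound 2 to compound 3 (0.15 log units; within the scatter), and it lies within the scatter. It involves an aromatic carbon, so it offers only weak guidance for a change on a saturated ring. In this assay, the expected change is small and slightly upward, at a 1.3-fold higher number from compound 2 to compound 4 (0.10 log units; within the scatter), which is not expected to exceed the scatter. For compound 4, the estimated clearance is 5 mL/min/kg, with an expected range of 2.5 mL/min/kg to 10 mL/min/kg.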

Compound 4, clearance: 5.6 mL/min/kg
Compound 4: middle estimate off by 1.1-fold (0.05 log units), on the low side; the range from low to high includes it.
By their numbers in this assay, from the lowest: compounds 2, 3 and 4 (each within the scatter of the next).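

In this assay, placing a methyl on the saturated ring carbon next to the ring nitrogen gives a 1.4-fold higher number from compound 2 to compound 4 (0.15 log units; within the scatter), so this added carbon leaves clearance within the scatter. Among these compounds, the earlier step changed only an aromatic carbon, so this is the first reading of a change on the saturated ring. No supporting measurement speaks to the reason for this result.

Going by these compounds, whether a larger group at this carbon, such as an ethyl chain or an amine, would also stay within the scatter remains open. So does the effect of the methyl's mirror-image form.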